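The source may report more compounds than this note shows. Statements on the series, on what has been measured and on what is new or still open speak of the compounds shown alone.

Compound 1 `CCOCc1cc(CCCOc2c(C)cc(-c3noc(C(F)(F)F)n3)cc2C)on1`: > 2.5 h
Compound 2 `CCc1cc(CCCOc2c(C)cc(-c3noc(C(F)(F)F)n3)cc2C)on1`: > 2.5 h

In an in vitro ADME assay on microsomes from liver (Simiiformes) (a higher number here means that the compound lasts longer, a lower number that the compound disappears faster), compound 2 gives > 2.5 h, which is a limit and not a number. Compound 1 gives > 2.5 h, also a limit. Compound 3 `Cc1cc(-c2noc(C(F)(F)F)n2)cc(C)c1OCCCc1cc(CO)no1` carries hydroxy in place of methyl on a saturated chain carbon bound to an aromatic carbon. Going by the values given here, the only measured step that bears on this is a step that the two limits leave unreadable from compound 1 to compound 2, so it supplies no size to carry over. In this assay no shift beyond the scatter is therefore expected, in either direction, and the expected step is a number no higher from compound 2 to compound 3 (the limit leaves the size open). The estimated half-life for compound 3 is 2.5 h, with an expected range of 1 h to 5 h.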

Compound 3, half-life: > 2.5 h
Compound 3 was reported as a limit; the forecaster's own chance of this, stated with the estimate: 55%; the middle value sits exactly at the limit.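

In this assay, going by these compounds alone, compound 3 is reported only as a limit, so no step among compound 1, compound 2 and compound 3 can be read: the limit of > 2.5 h in this assay, at which 3 of the 3 values shown sit.

From the compounds shown here alone, how far the half-lives of these three compounds differ stays open.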